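A few compounds are considered here, and "the series" means these few. Any claim that something is new, unique, unknown or untested is made for them only; others in the source may bear on it.

Working notes on the series. In a functional assay on HeLa cells (Homo sapiens) for antiproliferative activity, read by CCK-8 assay, with a stated time of 72 h, tested at 2 uM (on this read-out higher numbers stand for a stronger effect at the one concentration tested and lower numbers for a weaker effect), compound 3 `CCN(Cc1ccncc1)C(=S)SCc1ccc(C(=O)Nc2ccccc2N)cc1` gives 63.5% and stands highest of the three measured numbers. Compound 1 `CN(C(=S)SCc1ccc(C(=O)Nc2ccccc2N)cc1)c1cccnc1` gives 16% and compound 2 `Nc1ccccc1NC(=O)c1ccc(CSC(=S)N2CCCc3ccccc32)cc1` gives 26.1% in the same assay. The steps of a number 47.5 percentage points higher from compound 1 to compound 3 (beyond the scatter) and a number 37.4 percentage points higher from compound 2 to compound 3 (beyond the scatter) are both large, and each one swaps the whole amino group on the thiocarbonyl carbon. Compound 4 `CN(Cc1ccncc1)C(=S)SCc1ccc(C(=O)Nc2ccccc2N)cc1` differs from compound 3 only by hydrogen in place of methyl on a saturated chain carbon bound to an amide-type nitrogen. For the measured compounds named here, none of the measured steps changes a piece this small, so none bears on it directly; they show only that the group on the thiocarbonyl carbon matters. The step is expected to stay within the scatter, estimated as a number 7.5 percentage points lower from compound 3 to compound 4 (within the scatter). Compound 4 is expected to give about 56%, between 38% and 72%.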

Compound 4, a percentage reported as inhibition, at one concentration (the size of the read-out at that concentration, not a potency): 29.5%
Estimate against measurement, compound 4: 26.5 percentage points above; the whole stated range lies above it.
By their numbers in this assay, from the lowest: compound 1; then compounds 2 and 4 (each within the scatter of the next); then compound 3.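

In this assay, a change of a single carbon, ethyl to methyl within the ethyl((pyridin-4-yl)methyl)amino group, gives a number 34 percentage points lower from compound 3 to compound 4 (beyond the scatter) and so counts for as much as the whole-group swaps. The methyl((pyridin-4-yl)methyl)amino group gives a number 3.4 percentage points higher from compound 2 to compound 4 (within the scatter) against 1,2,3,4-tetrahydroquinolin-1-yl, while (pyridin-4-yl)methyl in place of pyridin-3-yl gives a number 13.5 percentage points higher from compound 1 to compound 4 (beyond the scatter) and only a modest gain. Nothing available accounts for the size of this drop. From the compounds shown here alone, whether propyl or a longer chain in place of ethyl holds or raises the number stays open.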